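Isoxazole series: phenyl to 2-phenylethenyl on the shared core

The source may hold more compounds than are shown below. What is called first, only, known or untested is meant among the compounds shown, and "the series" means these compounds.

Compound 2 `O=C1C[C@H](OCc2cc(-c3ccccc3)no2)[C@H]2CO[C@@H]1O2` carries the shared core with a phenyl group on the five-membered ring. In a functional assay on NCI-H1299 cells (Homo sapiens) for cytotoxicity, read by MTT assay, with a stated time of 48 h (a lower number here means a stronger inhibitor, a higher number a weaker inhibitor), compound 2 gives 9800 nM. Compound 1 `O=C1C[C@H](OCc2cn(-c3ccc([N+](=O)[O-])cc3)nn2)[C@H]2CO[C@@H]1O2` gives 10300 nM, and compound 3 `O=C1C[C@H](OCc2cc(-c3ccc([N+](=O)[O-])cc3)no2)[C@H]2CO[C@@H]1O2` gives 11200 nM; both numbers lie within the scatter of the number for compound 2, so the three measured compounds cannot be ranked.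

Compound 4 `O=C1C[C@H](OCc2cc(/C=C/c3ccccc3)no2)[C@H]2CO[C@@H]1O2` is not yet measured. It differs from compound 2 by 2-phenylethenyl in place of phenyl on an aromatic carbon. Among the compounds with values here, the only measured step that touches the same part of the structure is a 1.1-fold higher number from compound 2 to compound 3 (0.06 log units; within the scatter), which left the number unchanged beyond the scatter. Within the data shown here, no measured pair exchanges phenyl for 2-phenylethenyl, so the step to compound 4 has no direct precedent.

Given that the one change at this position, from compound 2 to compound 3, stayed within the scatter, the step of a 1.1-fold lower number from compound 2 to compound 4 (0.04 log units; within the scatter) from compound 2 to compound 4 is expected to be small. Compound 4 is estimated at 9000 nM in this assay, within a range from 3000 nM to 27000 nM.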

Compound 4, half-maximal inhibitory concentration: 7100 nM
For compound 4 the middle estimate is 1.3-fold (0.10 log units) above the measured one; the range from low to high includes it.
By their numbers in this assay, from the lowest: compounds 4, 2, 1 and 3 (each within the scatter of the next).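

In this assay, 2-phenylethenyl in place of phenyl, on an aromatic carbon of the five-membered aromatic ring with 1 nitrogen and 1 oxygen, gives a 1.4-fold lower number from compound 2 to compound 4 (0.14 log units; within the scatter). The earlier step at this position changed only a substituent on the phenyl ring, whereas this one changes the group attached to the five-membered ring and adds a double bond outside aromatic rings, and the step still stays within the scatter. No supporting measurement bears on this result.

The four compounds shown still cannot be ranked, so it remains open whether any group at this position can move the number beyond the scatter. A longer chain in place of 2-phenylethenyl, or an amine or a carboxylic acid on its phenyl ring, would test this.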